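The source may report more compounds than this note shows. Statements on the series, on what has been measured and on what is new or still open speak of the compounds shown alone.

Going by the values given here, compound 2, with the structure `Cn1c(=O)[nH]c2c(cnn2-c2ccccc2)c1=N`, has the higher of the two numbers measured so far in an assay on membranes from brain for binding affinity to adenosine receptor A1 (Rattus norvegicus), read by radioligand binding, tested at 20 uM; a higher number here means more inhibition at the concentration tested (going by the name of the read-out), a lower number less inhibition: compound 2 gives 30%. Its nearest neighbour is compound 1, with the structure `Cn1c(=O)[nH]c2c(cnn2-c2cccc([N+](=O)[O-])c2)c1=N`, which in this assay gives 2%. The two share one core, and the change from compound 1 to compound 2, hydrogen in place of nitro on an aromatic carbon, gave a number 28 percentage points higher from compound 1 to compound 2 (beyond the scatter), a modest but real rise.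

Compound 3, with the structure `Cn1c(=O)[nH]c2c(cnn2-c2cccc(N)c2)c1=N`, is the next compound to be measured. It differs from compound 2 as follows: amino in place of hydrogen on an aromatic carbon. Among the compounds with values here, the only measured step that bears on a change at an aromatic carbon is the one from compound 1 to compound 2, which was modest in size. Adding an amino group is a different kind of change, so that single step gives no firm guide; a small move in either direction, or none beyond the scatter, seems about equally plausible. The step from compound 2 to compound 3 is therefore expected to be a number 5 percentage points lower from compound 2 to compound 3 (within the scatter). Compound 3 is expected to give about 25%, within a range from 5% to 50%.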

Compound 3, a percentage reported as inhibition, at one concentration (the size of the read-out at that concentration, not a potency): 0%
The estimate for compound 3 lay 25 percentage points above the measured number, and the stated range ends above it.
By their numbers in this assay, from the lowest: compounds 3 and 1 (each within the scatter of the next); then compound 2.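

In this assay, the ring position that carries nitro in compound 1 now has a second group, amino, and the change from hydrogen is a number 30 percentage points lower from compound 2 to compound 3 (beyond the scatter). Exchanging one of these groups for the other gives a number 2 percentage points lower from compound 1 to compound 3 (within the scatter), so this assay does not separate amino from nitro at this place, and both replacements of hydrogen tested here go with a lower number, something the nitro step alone could not show. Nothing measured here says why these two different groups end up with numbers this close.

The compounds shown leave open whether a methyl group or a chlorine atom at this same place would keep the number close to that of compound 2 or lower it as well. They also leave open whether amino or nitro at another position on the same ring would go with a similar fall, and since each number comes from a single concentration, none of them is a potency.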